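The source may hold more compounds than are shown below. What is called first, only, known or untested is meant among the compounds shown, and "the series" means these compounds.

Measured so far:
compound 1 `Cc1cccc(NC(=O)CN2CCN(c3ccc(Cl)cn3)CC2)c1`; in a functional assay on cells for antagonist activity at D(4) dopamine receptor (Homo sapiens), read by TR-FRET and cAMP accumulation, with a stated time of 30 min (on this read-out lower numbers stand for stronger inhibition and higher numbers for weaker inhibition), compound 1 gives 4700 nM.
compound 2 `CCc1cccc(NC(=O)CN2CCN(c3ccc(Cl)cn3)CC2)c1`; in this assay compound 2 gives 7060 nM.
compound 3 `O=C(CN1CCN(c2ccccn2)CC1)Nc1cncnc1`; in this assay compound 3 gives only a limit, > 100000 nM.

Among the measured compounds shown here, compound 3 stands at the edge of what this assay reports, the one compound here without a number, at the limit of > 100000 nM in this assay, at which 1 of the 3 values shown sits. Compound 4 `O=C(CN1CCN(c2ccc(Cl)cn2)CC1)Nc1cncnc1` differs from compound 3 by chloro in place of hydrogen on an aromatic carbon. For the measured compounds named here, the only measured step, a 1.5-fold higher number from compound 1 to compound 2 (0.18 log units; within the scatter), concerns a change at another place, so no measured step bears on this one. Compounds 1 and 2 carry the chloro group, but they differ from compound 3 in more than one place, so their numbers cannot be set against it. Compound 4 is expected to remain weak, estimated at 60000 nM, between 10000 nM and 200000 nM. The expected step from compound 3 is an at least 1.6-fold lower number from compound 3 to compound 4 (0.22 log units; that floor lies within the scatter).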

Compound 4, half-maximal inhibitory concentration: > 100000 nM
Compound 4 gave a limit, no number (the forecaster's own chance of this, stated with the estimate: 50%); middle value at least 1.6-fold (0.22 log units) from the limit.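

Compound 3 and compound 4 both end at a limit rather than a number, so the chloro step between them cannot be read: the limit of > 100000 nM in this assay, at which 2 of the 4 values shown sit.

What compound 4 adds concerns the group on the amide nitrogen: in this assay, with the 5-chloropyridin-2-yl group kept, pyrimidin-5-yl in place of 3-ethylphenyl gives an at least 14-fold higher number from compound 2 to compound 4 (1.15 log units; beyond the scatter), and pyrimidin-5-yl in place of 3-methylphenyl gives an at least 21-fold higher number from compound 1 to compound 4 (1.32 log units; beyond the scatter).

Going by these compounds, the size of the chloro step on a compound that gives a real number remains open. So does the effect of a methoxy group or an amine in place of the methyl on the 3-methylphenyl ring.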